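The source may hold more compounds than are shown below. What is called first, only, known or untested is meant among the compounds shown, and "the series" means these compounds.

Measured so far in a physicochemical assay for solubility, in phosphate buffer, measured as kinetic solubility, at pH 7.4; on this read-out lower numbers stand for lower solubility and higher numbers for higher solubility:

- compound 1 `Cc1ccc(C)c(-c2nc(CN3CCC(C(=O)NCCCN4C[C@H](C)C[C@H](C)C4)CC3)c(C)o2)c1`: 56.1 ug/mL
- compound 2 `Cc1oc(-c2ccccc2Cl)nc1CN1CCC(C(=O)NCCCN2C[C@H](C)C[C@H](C)C2)CC1`: > 72 ug/mL (a limit)
- compound 3 `Cc1ccccc1-c1nc(CN2CCC(C(=O)NCCCN3CCC(C(C)C)CC3)CC2)c(C)o1`: > 71 ug/mL (a limit)

Compound 3 stands at > 71 ug/mL, which is a limit and not a number. On these data alone, its exact position in this assay therefore stays open, and any comparison with it can only be loose.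

Compound 4 `Cc1ccccc1-c1nc(CN2CCC(C(=O)NCCCN3CCC(C)(C)CC3)CC2)c(C)o1` has not yet been measured. It carries 4,4-dimethylpiperidin-1-yl in place of 4-isopropylpiperidin-1-yl on a saturated chain carbon, three bonds along the chain from an amide-type nitrogen.

For the measured compounds named here, no measured step covers this change. The only one available is an at least 1.2-fold higher number from compound 1 to compound 2 (0.10 log units; that floor lies within the scatter), with 2-chlorophenyl in place of 2,5-dimethylphenyl on an aromatic carbon. It sits at a different place, and its size is only a floor that lies within the scatter. It gives weak support for a small step here, and no direction can be drawn from it.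

The estimated step is an at least 1.0-fold lower number from compound 3 to compound 4 (0.01 log units; that floor lies within the scatter), and nothing beyond the scatter is expected in either direction. Compound 4 may also be expected to return only a limit rather than a number. For compound 4 the expected value is 68 ug/mL, with an estimated range from 45 ug/mL to 90 ug/mL.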

Compound 4, solubility: > 69 ug/mL
Compound 4 ended at the assay's limit; the forecaster's own chance of this, stated with the estimate: 55%; at least 1.0-fold (0.00 log units) between middle value and limit.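

In this assay compound 3 stands at > 71 ug/mL, which is a limit. Compound 4 stands at > 69 ug/mL, also a limit, and no step can be read from compound 3 to compound 4. The compounds shown leave open whether 4,4-dimethylpiperidin-1-yl in place of 4-isopropylpiperidin-1-yl shifts the read-out in this assay at all.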